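Methoxy removal on the aryl ketone ring of the series

This account rests on a few compounds, and the source may have more. Where it says the series, first, only, none or still open, it means among the compounds named here.

Compound 1 `COc1ccc(-c2cc(/C=C/C(=O)c3ccc(N)cc3)[nH]n2)cc1` and compound 2 `COc1ccc(-c2cc(/C=C/C(=O)c3ccc(N)cc3)[nH]n2)cc1OC` share one core and differ by a single change, (hydrogen in place of methoxy on an aromatic carbon). In a functional assay on RXF 393 cells (Homo sapiens) for inhibition, read by sulforhodamine B assay, with a stated time of 48 h (on this read-out lower numbers stand for stronger inhibition of growth and higher numbers for weaker inhibition of growth), compound 1 gives 1670 nM, and compound 2 gives 2150 nM. The step between them is a 1.3-fold lower number from compound 2 to compound 1 (0.11 log units; within the scatter); both values sit within the scatter of each other, so no order is drawn from this pair.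

Compound 3 `COc1cc(C(=O)/C=C/c2cc(-c3cc(OC)c(OC)c(OC)c3)n[nH]2)cc(OC)c1OC` carries a different core; how its core differs from that of compound 2 is not broken down here. In this assay compound 3 gives 1260 nM. Its gaps to compound 1 and to compound 2 are both within the scatter.

Compound 4 `COc1ccc(-c2cc(/C=C/C(=O)c3cc(OC)c(OC)c(OC)c3)[nH]n2)cc1OC` is not yet measured. It arises from compound 3 by hydrogen in place of methoxy on an aromatic carbon. Going by the values given here, this is the same kind of change as the one from compound 2 to compound 1, but not the same: around the place in compound 3 the aromatic carbon is, in addition, meta to a methoxy group, which is absent around the place in compound 2.

The expectation for compound 4 rests on the earlier step, because a 1.3-fold lower number from compound 2 to compound 1 (0.11 log units; within the scatter) was within the scatter, and the expected step is a 1.1-fold lower number from compound 3 to compound 4 (0.06 log units; within the scatter), again within the scatter. For compound 4 in this assay the estimated value is 1100 nM, expected to lie between 500 nM and 2500 nM.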

Compound 4, concentration for 50% growth inhibition: 1530 nM
For compound 4 the middle estimate is 1.4-fold (0.14 log units) below the measured one; the range from low to high includes it.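

In this assay, hydrogen in place of methoxy on the core of compound 3, at an aromatic carbon ortho to a methoxy group and meta to a further methoxy group, gives a 1.2-fold higher number from compound 3 to compound 4 (0.08 log units; within the scatter). Set beside the same change on the core of compound 2, the step shows no measurable difference between the two cores: the same change on two cores in this assay, a 1.3-fold lower number (0.11 log units; within the scatter) from compound 2 to compound 1 and a 1.2-fold higher number (0.08 log units; within the scatter) from compound 3 to compound 4, 1.6-fold (0.19 log units) apart, within the scatter of two such steps This supports only a limited reading, that removing this methoxy group leaves no step beyond the scatter on either core; neither step has a size or direction that could be carried to a further core, and the opposite wording of the two steps carries no weight.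

The compounds shown cover only methoxy and hydrogen at this place, so a step beyond the scatter has yet to be seen for any change there. On these data alone, whether a hydroxyl group, a chlorine atom or a carboxylic acid at the same aromatic carbon would give such a step on either core, and whether the two cores would then still agree, remains open.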